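The compounds below may be only part of what the source reports. "The series", "measured", "known", "first", "only" and "open" are said of these compounds alone.

Three compounds share one core and differ only in the aromatic group attached to it. Compound 1 `CCOC(=O)CCCCCOc1cccc(CN(C(=O)c2ccc(-c3cccc4ccccc34)cc2)C(C)C)c1` carries a naphthalen-1-yl group. In an ADME assay on HepG2 cells (Homo sapiens) for cytotoxicity, read by CellTiter-Glo and resazurin assay, with a stated time of 72 h (on this read-out lower numbers stand for an effect already at smaller amounts and higher numbers for an effect only at larger amounts of compound), compound 1 gives > 26000 nM, which is a limit of the assay rather than a number. Compound 2 `CCOC(=O)CCCCCOc1cccc(CN(C(=O)c2ccc(-c3ccc4ccccc4c3)cc2)C(C)C)c1` carries naphthalen-2-yl in the same position. In this assay compound 2 gives > 26000 nM, again only a limit. Compound 3 `CCOC(=O)CCCCCOc1cccc(CN(C(=O)c2ccc(-c3ccncc3)cc2)C(C)C)c1` carries pyridin-4-yl there. In this assay compound 3 gives > 26000 nM, also a limit. Because all three values sit at the limit of > 26000 nM in this assay, at which 3 of the 3 values shown sit, the step that the two limits leave unreadable from compound 1 to compound 2, the step that the two limits leave unreadable from compound 1 to compound 3 and the step that the two limits leave unreadable from compound 2 to compound 3 cannot be read in size or direction. Compound 3 thus stands at the limit, like the two others. Compound 4 `CCOC(=O)CCCCCOc1cccc(CN(C(=O)c2ccc(-c3cnc(OC)nc3OC)cc2)C(C)C)c1` differs from it in one place: 2,4-dimethoxypyrimidin-5-yl in place of pyridin-4-yl on an aromatic carbon. Going by the values given here, no measured step offers a readable size, so no shift beyond the scatter is expected, and the step that the limit leaves unreadable from compound 3 to compound 4 is estimated as none. Compound 4 is expected to give 40000 nM, within 20000 nM to 100000 nM, most likely again reported only as a limit.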

Compound 4, half-maximal effective concentration: > 26000 nM
Compound 4: only a limit was reported; the forecaster's own chance of this, stated with the estimate: 85%; the middle value is on the limit's open side.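

Compound 4 also gives only a limit in this assay, so no step from compound 1, compound 2 or compound 3 to compound 4 can be read: the limit of > 26000 nM in this assay, at which 4 of the 4 values shown sit.

The compounds shown leave open where each true value lies beyond that limit, and so whether the four aromatic groups differ at all.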